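The source may report more compounds than this note shows. Statements on the series, on what has been measured and on what is new or still open speak of the compounds shown alone.

Three close relatives of one shared core were tested in a functional assay on HeLa cells (Homo sapiens) for antiproliferative activity, read by MTT assay, with a stated time of 24 h; on this read-out higher numbers stand for weaker inhibition and lower numbers for stronger inhibition. Compound 1 `c1ccc(CSc2nnc(-c3ccc4c(c3)OCCO4)n2-c2ccccc2)cc1` gives 32800 nM there, the second highest of the three numbers. Compound 2 `Cc1ccccc1CSc1nnc(-c2ccc3c(c2)OCCO3)n1-c1ccccc1` gives 36000 nM, and compound 3 `Fc1ccccc1CSc1nnc(-c2ccc3c(c2)OCCO3)n1-c1ccccc1` gives 24300 nM. Both steps out of compound 1 stay within the scatter: a 1.1-fold higher number from compound 1 to compound 2 (0.04 log units; within the scatter) and a 1.3-fold lower number from compound 1 to compound 3 (0.13 log units; within the scatter). Compound 4 `Fc1cccc(F)c1CSc1nnc(-c2ccc3c(c2)OCCO3)n1-c1ccccc1` has not yet been measured; it differs from compound 1 by 2,6-difluorophenyl in place of phenyl on a saturated chain carbon bound to a sulfur. Among the compounds with values here, the single fluoro step from compound 1 to compound 3 is the only one that bears on this change, and it was small, so no change beyond the scatter is expected in this assay. The expected step is a 1.5-fold lower number from compound 1 to compound 4 (0.17 log units; within the scatter). Compound 4 is therefore estimated at 22000 nM, with a range from 10000 nM to 45000 nM.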

Compound 4, half-maximal inhibitory concentration: 35200 nM
Compound 4: middle estimate off by 1.6-fold (0.20 log units), on the low side; the range from low to high includes it.
By their numbers in this assay, from the lowest: compounds 3, 1, 4 and 2 (each within the scatter of the next).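

In this assay, 2,6-difluorophenyl in place of phenyl on a saturated chain carbon bound to a sulfur gives a 1.1-fold higher number from compound 1 to compound 4 (0.03 log units; within the scatter), so two fluorines on this ring leave the number as unmoved as one did. A further fluoro in place of hydrogen gives a 1.4-fold higher number from compound 3 to compound 4 (0.16 log units; within the scatter), and 2,6-difluorophenyl in place of 2-methylphenyl gives a 1.0-fold lower number from compound 2 to compound 4 (0.01 log units; within the scatter), so the four compounds do not separate. No other measurement helps to interpret this result. On these data alone, whether a benzyl group carrying an amine or a carboxylic acid, or a longer chain in its place, would give a step beyond the scatter stays open.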